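The compounds below may be only part of what the source reports. "The series", "measured", "known", "first", "only" and "open" are said of these compounds alone.

Values measured in a functional assay on MCF7 cells (Homo sapiens) for antiproliferative activity, read by MTT assay, with a stated time of 72 h (a lower number here means a stronger inhibitor, a higher number a weaker inhibitor), follow
- Compound 1 `COc1cccc(-c2ncnn2-c2cc(OC)c(OC)c(OC)c2)c1` gives > 10000 nM (a limit)
- Compound 2 `COc1cc(-n2ncnc2-c2ccc(Cl)c(Cl)c2)cc(OC)c1OC` gives > 10000 nM (a limit)
- Compound 3 `COc1cc(-n2ncnc2-c2cccc(Cl)c2)cc(OC)c1OC` gives > 10000 nM (a limit)

In this assay compound 3 gives > 10000 nM as a limit of the assay and not a number. The whole series sits at the limit of > 10000 nM in this assay, at which 3 of the 3 values shown sit, with no number by which to rank its members.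

The next structure is compound 4 `COc1ccccc1-c1ncnn1-c1cc(OC)c(OC)c(OC)c1` and the change is 2-methoxyphenyl in place of 3-chlorophenyl on an aromatic carbon with 2-methoxyphenyl in place of 3-chlorophenyl on an aromatic carbon, between two ring nitrogen atoms.

Among the compounds with values here, three measured steps concern this same group: a step that the two limits leave unreadable from compound 1 to compound 2 then a step that the two limits leave unreadable from compound 1 to compound 3 and finally a step that the two limits leave unreadable from compound 2 to compound 3 as the third. None of them has a readable size, so they offer no direction for the new exchange. Compound 1 carries a 3-methoxyphenyl group and still gives > 10000 nM as a limit of the assay. On that reason, a methoxy-bearing phenyl is not expected to bring compound 4 to a measurable value in this assay and no step beyond the scatter is expected in either direction. The expected change is a step that the limit leaves unreadable from compound 3 to compound 4 and no more than that is estimated. Compound 4 is estimated at 15000 nM with an expected range from 5000 nM to 50000 nM and will most likely be reported as a limit again.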

Compound 4, half-maximal inhibitory concentration: > 10000 nM
Compound 4 gave a limit, no number; the forecaster's own chance of this, stated with the estimate: 85%; the middle value lies beyond the limit too.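

Compound 4 also ends at a limit of the assay and not a number, and its steps from compound 1, compound 2 and compound 3 cannot be read in this assay. All four compounds now sit together: the limit of > 10000 nM in this assay, at which 4 of the 4 values shown sit. The compounds shown leave open how these four rank against one another and whether any exchange of the phenyl group on the shared core brings a measurable value.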